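Chain shortening in the thioether-linked xanthine series

The compounds below may be only part of what the source reports. "The series", "measured", "known", "first", "only" and "open" are said of these compounds alone.

Among the compounds with values here, compound 2 `Cn1c(=O)c2c(nc(SCCc3cccc(Br)c3)n2C)n(C)c1=O` gives 40 nM in an assay on microsomes for inhibition of Amine oxidase [flavin-containing] B (Homo sapiens), read by fluorescence and spectrophotometry, with a stated time of 20 min (a higher number here means a weaker inhibitor, a lower number a stronger inhibitor), the lower of the two numbers known so far, though within the scatter of compound 1 `Cc1ccc(CCSc2nc3c(c(=O)n(C)c(=O)n3C)n2C)cc1` with 72 nM. Within the data shown here, the one measured step, a 1.8-fold lower number from compound 1 to compound 2 (0.26 log units; within the scatter), changed the aryl group and leaves the chain untouched. Among the measured compounds shown here, compound 3 `Cn1c(=O)c2c(nc(SCc3cccc(Br)c3)n2C)n(C)c1=O` differs from compound 2 by 3-bromophenyl in place of 3-bromobenzyl on a saturated chain carbon bound to a sulfur, a shortening of the linker that no measured step bears on. For the measured compounds named here, with no comparable step known, no shift beyond the scatter is expected, and the range is set wide. Compound 3 is estimated at 60 nM (range 15 nM to 250 nM), an expected step of a 1.5-fold higher number from compound 2 to compound 3 (0.18 log units; within the scatter).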

Compound 3, half-maximal inhibitory concentration: 199 nM
For compound 3 the middle estimate is 3.3-fold (0.52 log units) below the measured one; low and high end bracket the measured number.
By their numbers in this assay, from the lowest: compounds 2 and 1 (each within the scatter of the next); then compound 3.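

In this assay the linker position responds beyond the scatter, which the aryl change did not: 3-bromophenyl in place of 3-bromobenzyl on a saturated chain carbon bound to a sulfur gives a 5.0-fold higher number from compound 2 to compound 3 (0.70 log units; beyond the scatter) and so shortening costs potency here. With 4-methylbenzyl as the starting group, the replacement gives a 2.8-fold higher number from compound 1 to compound 3 (0.44 log units; beyond the scatter) in the same direction, and neither compound with the longer linker goes against this. No data at hand explain these steps.

From the compounds shown here alone, whether a longer chain than that of compound 2 would lower the number stays open. So does the effect of an amine or a carboxylic acid on the aromatic ring.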